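Exchanging a Halogenated Phenyl Ring on a Weak Inhibitor

The source may report more compounds than this note shows. Statements on the series, on what has been measured and on what is new or still open speak of the compounds shown alone.

Compound 1 `COc1ccc(-n2nncc2CN2C(=O)C3(C(C#N)=C(N)Oc4c3c3nc5ccccc5nc3c3ccccc43)c3ccccc32)cc1`: > 50000 nM
Compound 2 `N#CC1=C(N)Oc2c(N)cc3nc4ccccc4nc3c2C12C(=O)N(Cc1cnnn1-c1ccccc1Br)c1ccccc12`: 30700 nM

Of the compounds shown here, two have been tested in a functional assay on MCF7 cells (Homo sapiens) for antiproliferative activity, read by MTT assay, with a stated time of 48 h; a lower number here means a stronger inhibitor, a higher number a weaker inhibitor. For compound 1 the result is only an assay limit, > 50000 nM. Among the compounds with values here, compound 2 gives the sole number, 30700 nM, and therefore stands alone as a weak inhibitor. Compound 3 `N#CC1=C(N)Oc2c(N)cc3nc4ccccc4nc3c2C12C(=O)N(Cc1cnnn1-c1c(Cl)cc(Cl)cc1Cl)c1ccccc12` differs from compound 2 in one place: 2,4,6-trichlorophenyl in place of 2-bromophenyl on an aromatic nitrogen. Within the data shown here, no step between measured compounds exists, so the structural change alone is the guide, and a step within the scatter, in either direction, is expected: a 1.1-fold lower number from compound 2 to compound 3 (0.04 log units; within the scatter). Compound 3 is estimated at 28000 nM, between 9000 nM and 90000 nM.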

Compound 3, half-maximal inhibitory concentration: 37800 nM
Compound 3: the middle estimate sits 1.4-fold (0.13 log units) below what was measured; measured number inside the range.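

Placing 2,4,6-trichlorophenyl where 2-bromophenyl stood on the aromatic nitrogen gives a 1.2-fold higher number from compound 2 to compound 3 (0.09 log units; within the scatter) in this assay. This first reading at this position shows that the two groups cannot be told apart here, even though one carries a single bromine and the other three chlorines. Compound 1 gives only a limit of the assay: the limit of > 50000 nM in this assay, at which 1 of the 3 values shown sits.

Still open, from the compounds shown here alone, is whether an unsubstituted phenyl ring, or a phenyl ring carrying an amine or a carboxylic acid, would move the number at this position beyond the scatter.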